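This account rests on a few compounds, and the source may have more. Where it says the series, first, only, none or still open, it means among the compounds named here.

Series in a functional assay on MCF7 cells (Homo sapiens) for antiproliferative activity, read by MTT assay, with a stated time of 48 h; a lower number here means a stronger inhibitor, a higher number a weaker inhibitor:
compound 1 `C=C(c1ccc(OC)cc1NC(=O)CO)c1ccc(OC)c2c1OC(C)(C)C=C2` gives 100 nM
compound 2 `C=C(c1ccc(OC)cc1NC(=O)CN)c1ccc(OC)c2c1OC(C)(C)C=C2` gives 220 nM
compound 3 `C=C(c1ccc(OC)cc1NC(=O)CNC)c1ccc(OC)c2c1OC(C)(C)C=C2` gives 400 nM

Compound 3 has the highest number of the three, but only the gap to compound 1 counts: a 4.0-fold higher number from compound 1 to compound 3 (0.60 log units; beyond the scatter), whereas a 1.8-fold higher number from compound 2 to compound 3 (0.26 log units; within the scatter).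

Compound 4 `C=C(c1ccc(OC)cc1NC(=O)CNCC)c1ccc(OC)c2c1OC(C)(C)C=C2` follows from compound 3 by methyl in place of hydrogen on a saturated chain carbon bound to an amine nitrogen, so methylamino becomes ethylamino.

Among the compounds with values here, no measured step makes this change. The closest is the added methyl on the amine nitrogen, a 1.8-fold higher number from compound 2 to compound 3 (0.26 log units; within the scatter), so only a small rise, none beyond the scatter, is expected in this assay.

The expected step is a 1.3-fold higher number from compound 3 to compound 4 (0.10 log units; within the scatter).

For compound 4 the estimate is 500 nM, with an expected range of 220 nM to 1100 nM.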

Compound 4, half-maximal inhibitory concentration: 2100 nM
The estimate for compound 4 lay 4.2-fold (0.62 log units) below the measured number; measured number outside the range, above it.
By their numbers in this assay, from the lowest: compound 1; then compounds 2 and 3 (each within the scatter of the next); then compound 4.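

In this assay the saturated chain carbon bound to the amine nitrogen proves sensitive: methyl in place of hydrogen there gives a clear step (a 5.3-fold higher number from compound 3 to compound 4 (0.72 log units; beyond the scatter)), unlike methyl on the amine nitrogen itself (a 1.8-fold higher number from compound 2 to compound 3 (0.26 log units; within the scatter)). Ethylamino also stands well apart from amino (a 9.5-fold higher number from compound 2 to compound 4 (0.98 log units; beyond the scatter)) and from hydroxy (a 21-fold higher number from compound 1 to compound 4 (1.32 log units; beyond the scatter)). No measurement at hand bears on why this step is so large.

From the compounds shown here alone, whether propylamino or dimethylamino continues this rise stays open. So does whether a cyclic amine such as pyrrolidine behaves like ethylamino.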